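Swapping Hydroxy for Chloro on a Cytotoxic Core

A few compounds are considered here, and "the series" means these few. Any claim that something is new, unique, unknown or untested is made for them only; others in the source may bear on it.

Compound 1, `COc1ccc(-c2ccnc(Nc3ccc4c(c3)c(/C=C3/C(=O)Nc5ccccc53)cn4C)n2)cc1`: in a functional assay on LNCaP cells (Homo sapiens) for cytotoxicity, read by MTT assay, with a stated time of 48 h (a higher number here means a weaker inhibitor, a lower number a stronger inhibitor), compound 1 gives > 100000 nM, a limit of the assay rather than a number.
Compound 2, `Cn1cc(/C=C2/C(=O)Nc3ccccc32)c2cc(Nc3nccc(-c4ccc(O)cc4)n3)ccc21`: in this assay compound 2 gives 10800 nM.

Compound 2 thus holds the only real number shown; the other value is a limit. Compound 3, `Cn1cc(/C=C2/C(=O)Nc3ccccc32)c2cc(Nc3nccc(-c4ccc(Cl)cc4)n3)ccc21`, differs from compound 2 by chloro in place of hydroxy on an aromatic carbon. Among the compounds with values here, one measured step bears on it: an at least 9.2-fold lower number from compound 1 to compound 2 (0.96 log units; beyond the scatter), a change that brought in a hydrogen-bond donor. Because an at least 9.2-fold lower number from compound 1 to compound 2 (0.96 log units; beyond the scatter) went with that donor entering and compound 3 again carries none, compound 3 is expected to be weaker, a step of a 2.8-fold higher number from compound 2 to compound 3 (0.44 log units; beyond the scatter). The estimate for compound 3 is 30000 nM, between 8000 nM and 100000 nM, with a real chance that only a limit is reported.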

Compound 3, half-maximal inhibitory concentration: 6590 nM
The estimate for compound 3 lay 4.6-fold (0.66 log units) above the measured number, outside the stated range (below it).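

Chloro for hydroxy gives a 1.6-fold lower number from compound 2 to compound 3 (0.21 log units; within the scatter), so the hydrogen-bond donor of hydroxy is not needed at this position for this level of cytotoxicity. Methoxy is the group that stands apart, since chloro in its place gives an at least 15-fold lower number from compound 1 to compound 3 (1.18 log units; beyond the scatter). Compound 1 holds a limit rather than a number, so the true size of that step stays unknown: the limit of > 100000 nM in this assay, at which 1 of the 3 values shown sits.

Still open, going by these compounds, is whether an amine, a carboxylic acid or a longer chain such as ethoxy at this position would behave like hydroxy and chloro or like methoxy.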